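From a pyridylmethyl ether to a cyclopropylmethyl amine

The source may report more compounds than this note shows. Statements on the series, on what has been measured and on what is new or still open speak of the compounds shown alone.

Measured in an ADME assay (liver) for pharmacokinetics, with Liver microsome (Rattus norvegicus) as the target, read by LC-MS, using microsomes, tested at 2 uM; on this read-out higher numbers stand for fast clearance and lower numbers for slow clearance:
- compound 1 `O=C(N[C@@H]1CCCC[C@H]1O)c1cnc(OC2CCCCC2)c(-c2ccc(Cl)cc2)c1`: 0.662 mL/min/kg
- compound 2 `O=C(N[C@@H]1CCCC[C@H]1O)c1cnc(OCc2ccccc2)c(-c2ccc(Cl)cc2)c1`: 0.02 mL/min/kg
- compound 3 `O=C(N[C@@H]1CCCC[C@H]1O)c1cnc(OCc2ccncc2)c(-c2ccc(Cl)cc2)c1`: 0.118 mL/min/kg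

The three compounds share a core and differ only in the group on the oxygen. Compound 3 holds the middle place among the three numbers, second highest, with a 5.6-fold lower number from compound 1 to compound 3 (0.75 log units; beyond the scatter) and a 5.9-fold higher number from compound 2 to compound 3 (0.77 log units; beyond the scatter). The widest gap is a 33-fold lower number from compound 1 to compound 2 (1.52 log units; beyond the scatter).

Compound 4 `CN(CC1CC1)c1ncc(C(=O)N[C@@H]2CCCC[C@H]2O)cc1-c1ccc(Cl)cc1` departs from compound 3 at that same place, para to a (2-hydroxycyclohexyl)carbamoyl group: (cyclopropylmethyl)(methyl)amino in place of (pyridin-4-yl)methoxy on an aromatic carbon. In words, (cyclopropylmethyl)(methyl)amino comes in place of (pyridin-4-yl)methoxy on an aromatic carbon. Among the measured compounds shown here, no measured compound has a nitrogen attached there, so no measured step covers that part of the change directly.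

The nearest guide is compound 1, whose cyclohexyl, like the entering group, has no aromatic ring. Among these three compounds it gives the highest number, and the two steps away from it, a 33-fold lower number from compound 1 to compound 2 (1.52 log units; beyond the scatter) and a 5.6-fold lower number from compound 1 to compound 3 (0.75 log units; beyond the scatter), both lie beyond the scatter. For the measured compounds named here, a modest rise from compound 3 toward compound 1 therefore seems likely in this assay, though only three compounds support it. The expected change is a 2.5-fold higher number from compound 3 to compound 4 (0.41 log units; beyond the scatter). For compound 4 the estimated value is 0.3 mL/min/kg, expected to fall between 0.06 mL/min/kg and 1.4 mL/min/kg.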

Compound 4, clearance: 1.73 mL/min/kg
For compound 4 the middle estimate is 5.8-fold (0.76 log units) below the measured one; measured number above the stated range.
By their numbers in this assay, from the lowest: compound 2; then compound 3; then compound 1; then compound 4.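

In this assay, compound 4 gives the highest number of the four, and (cyclopropylmethyl)(methyl)amino on this aromatic carbon next to the ring nitrogen stands far from both aromatic ethers, with a 15-fold higher number from compound 3 to compound 4 (1.17 log units; beyond the scatter) and an 87-fold higher number from compound 2 to compound 4 (1.94 log units; beyond the scatter). The rise persists against the other group without an aromatic ring, with a 2.6-fold higher number from compound 1 to compound 4 (0.42 log units; beyond the scatter), so the absence of an aromatic ring does not by itself set the top of the range here. Among the compounds shown here, of the earlier compounds, all joined through oxygen, the top number belongs to compound 1, with 0.662 mL/min/kg, and compound 4 shows that this position can carry a number beyond that one.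

The step from compound 1 to compound 4 changes both the linking atom and the group attached to it, so the compounds shown cannot tell which of the two goes with the higher number; a cyclopropylmethoxy group or a benzylamino group on the same carbon would separate them. Nothing available here offers an explanation for the rise.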